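Ring-amide nitrogen substitution in the alkyne series

The source may hold more compounds than are shown below. What is called first, only, known or untested is meant among the compounds shown, and "the series" means these compounds.

Measured compounds:
- compound 1, `Cc1ccc(C#Cc2ccc3c(n2)CCN(C)C3=O)cc1`, 1400 nM
- compound 2, `CN1CCc2nc(C#Cc3cccc(Cl)c3)ccc2C1=O`, 22 nM
- compound 3, `CN1CCc2nc(C#Cc3cccnc3)ccc2C1=O`, "not active" (no number reported)

The three measured compounds share one core and differ only in the aryl group on the triple-bonded carbon. In a functional assay on HEK293 cells for negative allosteric modulation of metabotropic glutamate receptor 5 (Homo sapiens), read by FLIPR and calcium flux (a lower number here means a stronger inhibitor, a higher number a weaker inhibitor), compound 2 gives 22 nM, and the step of a 64-fold lower number from compound 1 to compound 2 (1.80 log units; beyond the scatter) shows how much that aryl group matters. Compound 3, with a pyridyl group there, is reported in this assay as "not active" (no number reported), so no number stands for it and it sits apart from compounds 1 and 2, both of which gave measurable inhibition.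

Compound 4, `CC(C)N1CCc2nc(C#Cc3cccnc3)ccc2C1=O`, keeps the pyridyl group of compound 3 and changes only the other end of the core: isopropyl in place of methyl on an amide-type nitrogen in a ring. For the measured compounds named here, none of the measured steps touches this position; the single measured step concerns the aryl group on the triple-bonded carbon and says nothing about the amide-type nitrogen. Going by the values given here, the only guide is compound 3 itself, which in this assay gave "not active" (no number reported), and a change at a distant position has no measured precedent here to move that outcome.

Compound 4 is therefore expected to give no measurable inhibition in this assay, with an estimate of 15000 nM and an expected range of 3000 nM to 60000 nM.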

Compound 4, half-maximal inhibitory concentration: "not active" (no number reported)
For compound 4 the study gives words and no number, and the estimate cannot be compared.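

In this assay compound 3 gives "not active" (no number reported) and compound 4 gives "not active" (no number reported), so no step can be read for isopropyl in place of methyl. The compounds shown leave open whether this change on the amide-type nitrogen in a ring alters inhibition when the aryl group gives a measurable value. No supporting data bear on this result.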